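Tert-butylphenyl to dimethylphenyl on the propanamide analogue

A few compounds are considered here, and "the series" means these few. Any claim that something is new, unique, unknown or untested is made for them only; others in the source may bear on it.

Compound 3 `CC(C(=O)NCC(COC(=O)C(C)(C)C)Cc1ccc(C(C)(C)C)cc1)c1ccc(NS(C)(=O)=O)cc1` gives 52 nM in a functional assay on CHO cells for antagonist activity at transient receptor potential cation channel subfamily V member 1 (Rattus norvegicus) (on this read-out higher numbers stand for weaker inhibition and lower numbers for stronger inhibition), the lowest of the three numbers; compound 1 `Cc1ccc(CC(CNC(=O)C(C)(C)c2ccc(NS(C)(=O)=O)cc2)COC(=O)C(C)(C)C)cc1C` gives 104 nM, within the scatter of it, and compound 2 `COc1cc(C(C)(C)C(=O)NCC(COC(=O)C(C)(C)C)Cc2ccc(C)c(C)c2)ccc1NS(C)(=O)=O` gives 133 nM, beyond it. Among the compounds with values here, the only one-place step measured, a 1.3-fold higher number from compound 1 to compound 2 (0.11 log units; within the scatter), concerns the methoxy and does not bear on the change to compound 4 `Cc1ccc(CC(CNC(=O)C(C)c2ccc(NS(C)(=O)=O)cc2)COC(=O)C(C)(C)C)cc1C`, which is 3,4-dimethylphenyl in place of 4-(tert-butyl)phenyl on a saturated chain carbon, three bonds along the chain from an amide-type nitrogen and an oxygen next to a carbonyl group. Compound 1 and compound 3 differ in two places, so their values only hint that the dimethylphenyl series runs near the tert-butylphenyl one. Within the data shown here, with no direct step, compound 4 is expected to move a 1.5-fold higher number from compound 3 to compound 4 (0.19 log units; within the scatter), no more than the scatter. Compound 4 is estimated at 80 nM, between 35 nM and 180 nM.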

Compound 4, inhibition constant: 38 nM
Compound 4: middle estimate off by 2.1-fold (0.32 log units), on the high side; the measured number falls inside the stated range.
By their numbers in this assay, from the lowest: compounds 4, 3, 1 and 2 (each within the scatter of the next, the first and the last beyond it).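

Here 3,4-dimethylphenyl in place of 4-(tert-butyl)phenyl gives a 1.4-fold lower number from compound 3 to compound 4 (0.14 log units; within the scatter) and leaves the two groups unseparated at this saturated chain carbon. Hydrogen in place of methyl on the carbon bound to the aromatic ring and the carbonyl gives a 2.7-fold lower number from compound 1 to compound 4 (0.44 log units; beyond the scatter) and is the only one-place step shown that lies beyond the scatter, though it is modest and rests on one pair. No measurement offered here bears on the cause of either step. Still open, as far as these compounds go, is how a plain benzyl or a 4-chlorobenzyl group would read at the first position. Also open, from the compounds shown here alone, is whether an ethyl group or a second hydrogen on the carbon bearing the methyl would extend the step from compound 1.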